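This account rests on a few compounds, and the source may have more. Where it says the series, first, only, none or still open, it means among the compounds named here.

Compound 1 `O=C(NCc1ccc(S(=O)(=O)c2cncc(C(F)(F)F)c2)cc1)N1Cc2ccncc2C1`: in a functional assay on A2780 cells (Homo sapiens) for cytotoxicity, read by sulforhodamine B assay, with a stated time of 72 h (on this read-out higher numbers stand for weaker inhibition and lower numbers for stronger inhibition), compound 1 gives 10 nM.
Compound 2 `O=C(NCc1ccc(S(=O)(=O)c2cc(F)cc(F)c2)cc1)N1Cc2ccncc2C1`: compound 2 gives 6.3 nM.
Compound 3 `CN1CCC(S(=O)(=O)c2ccc(CNC(=O)N3Cc4ccncc4C3)cc2)CC1`: compound 3 gives 99 nM.

Compound 1 stands second highest of the three numbers in this assay. Its nearest neighbour is compound 2, with a 1.6-fold lower number from compound 1 to compound 2 (0.20 log units; within the scatter), a step within the scatter; its furthest is compound 3, with a 9.9-fold higher number from compound 1 to compound 3 (1.00 log units; beyond the scatter).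

Compound 4 `O=C(NCc1ccc(S(=O)(=O)N2CC3(CCOCC3)C2)cc1)N1Cc2ccncc2C1` differs from compound 1 in one place: a group of 9 heavy atoms (7 carbon, 1 nitrogen, 1 oxygen; one four-membered non-aromatic ring with 1 hetero atom, one six-membered non-aromatic ring with 1 hetero atom) in place of a group of 10 heavy atoms (6 carbon, 1 nitrogen, 3 fluorine; one six-membered aromatic ring with 1 hetero atom), on a sulfonyl sulfur. Within the data shown here, the steps that bear on this change are the two in which an aromatic group on the sulfonyl sulfur gives way to a non-aromatic one: a 9.9-fold higher number from compound 1 to compound 3 (1.00 log units; beyond the scatter) and a 16-fold higher number from compound 2 to compound 3 (1.20 log units; beyond the scatter), both beyond the scatter. Among the measured compounds shown here, the group entering in compound 4 is likewise built only from non-aromatic rings, though no measured compound carries this particular group, and the range is widened accordingly. A rise in the number beyond the scatter is expected for compound 4, namely a 6.0-fold higher number from compound 1 to compound 4 (0.78 log units; beyond the scatter). The estimate for compound 4 is 60 nM, with a range from 15 nM to 250 nM.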

Compound 4, half-maximal inhibitory concentration: 10 nM
For compound 4 the middle estimate is 6.0-fold (0.78 log units) above the measured one; the whole stated range lies above it.
By their numbers in this assay, from the lowest: compounds 2, 1 and 4 (each within the scatter of the next); then compound 3.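

In this assay, an aromatic group on the sulfonyl sulfur proves not to be needed for a low number: the two-ring non-aromatic group in compound 4 gives no change at the digits printed from compound 1 to compound 4 (within the scatter), and likewise a 1.6-fold higher number from compound 2 to compound 4 (0.20 log units; within the scatter). Among non-aromatic groups at this place the outcome differs, with a 9.9-fold lower number from compound 3 to compound 4 (1.00 log units; beyond the scatter), so the high number of compound 3 goes with 1-methylpiperidin-4-yl and not with the loss of an aromatic ring as such. No measurement at hand accounts for these steps.

From the compounds shown here alone, whether a simpler non-aromatic group on the sulfonyl sulfur, such as morpholine or unsubstituted azetidine, would fall with compound 4 or with compound 3 remains open. So does the outcome for a group carrying a carboxylic acid or a primary amine at this place.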